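Swapping Trifluoromethyl for Methyl on an Inactive Sulfone

The compounds below may be only part of what the source reports. "The series", "measured", "known", "first", "only" and "open" are said of these compounds alone.

Compound 2, `O=[N+]([O-])c1cc(S(=O)(=O)C(F)(F)F)ccc1NC1CCCCC1`, is one of two measured members of this small set. In an assay on cells for inhibition of serine/threonine-protein kinase WNK1 (Homo sapiens), read by luminescence and Kinase-Glo, with a stated time of 2 h (a lower number here means a stronger inhibitor, a higher number a weaker inhibitor), compound 2 gives > 1000000 nM, which is a limit of the assay rather than a number. Its measured neighbour, compound 1, `O=[N+]([O-])c1cc(S(=O)(=O)C(Cl)(Cl)Br)ccc1NC1CCCCC1`, gives 4000 nM in this assay. Among the measured compounds shown here, the one measured step, an at least 250-fold higher number from compound 1 to compound 2 (2.39 log units; beyond the scatter), therefore ends at the limit of > 1000000 nM in this assay, at which 1 of the 2 values shown sits.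

For the measured compounds named here, the compound still to be measured is compound 3, `CS(=O)(=O)c1ccc(NC2CCCCC2)c([N+](=O)[O-])c1`. methyl in place of trifluoromethyl on a sulfonyl sulfur This change sits on the same sulfonyl sulfur as the measured step, which is the only guidance available, and that step ran toward weaker inhibition when the group on this sulfur was altered. Nothing measured here shows a gain in this assay from altering this group. For compound 3 the expected value in this assay is 1000000 nM, in a range from 100000 nM to 3000000 nM. The expected step, a number no higher from compound 2 to compound 3 (the limit leaves the size open), is none beyond the scatter, and a second reading at the limit is the most likely outcome.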

Compound 3, half-maximal inhibitory concentration: > 1000000 nM
Compound 3: a limit, no number (the forecaster's own chance of this, stated with the estimate: 80%); the middle value sits exactly at the limit.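

Methyl on the sulfonyl sulfur gives an at least 250-fold higher number from compound 1 to compound 3 (2.39 log units; beyond the scatter) and so joins trifluoromethyl at a limit, which means that two very different replacements for bromo(dichloro)methyl now end in the same place. Of the three groups shown on this sulfur, only bromo(dichloro)methyl gives a real number in this assay, so the measurable inhibition of compound 1 depends on that group rather than on the shared core alone. The step from compound 2 to compound 3 cannot be read, and methyl and trifluoromethyl cannot be ranked against each other, because both compounds sit at the same limit: the limit of > 1000000 nM in this assay, at which 2 of the 3 values shown sit.

What the compounds shown leave open is which part of bromo(dichloro)methyl matters, since no compound here changes its bromine or its chlorines one at a time. Trichloromethyl, or a longer chain such as ethyl, on the same sulfonyl sulfur would show whether a readable number can be obtained with any group other than the one in compound 1.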